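Trifluoromethyl and fluoro on the aryl ring of dienone series

A few compounds are considered here, and "the series" means these few. Any claim that something is new, unique, unknown or untested is made for them only; others in the source may bear on it.

Values in a functional assay on LNCaP cells (Homo sapiens) for cytotoxicity, read by MTT assay, with a stated time of 72 h; a lower number here means a stronger inhibitor, a higher number a weaker inhibitor:
compound 1 `CC1=C(/C=C/C(=O)/C=C/c2ccccc2C(F)(F)F)C(C)(C)CCC1O`: 2900 nM
compound 2 `CC1=C(/C=C/C(=O)/C=C/c2ccccc2F)C(C)(C)CCC1O`: 2900 nM
compound 3 `CC1=C(/C=C/C(=O)/C=C/c2cc(C(F)(F)F)ccc2F)C(C)(C)CCC1O`: 1700 nM

Compound 2 stands level with compound 1, the two together the highest numbers of the three; compound 3 lies below it by a 1.7-fold lower number from compound 2 to compound 3 (0.23 log units; within the scatter), inside the scatter. Compound 4 `CC1=C(/C=C/C(=O)/C=C/c2c(F)cccc2C(F)(F)F)C(C)(C)CCC1O` differs from compound 2 by trifluoromethyl in place of hydrogen on an aromatic carbon. Going by the values given here, two measured steps bear on this: a 1.7-fold lower number from compound 2 to compound 3 (0.23 log units; within the scatter), the same kind of entering group at another position, and no change at the digits printed from compound 1 to compound 2 (within the scatter), which shows trifluoromethyl and fluoro at the ortho site interchangeable. Neither step left the scatter, so no step beyond the scatter is expected in this assay for compound 4, with at most a small downward lean. Compound 4 is estimated at 2300 nM, range 1000 nM to 5000 nM, an expected step of a 1.3-fold lower number from compound 2 to compound 4 (0.10 log units; within the scatter).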

Compound 4, half-maximal inhibitory concentration: 4900 nM
Compound 4: middle estimate off by 2.1-fold (0.33 log units), on the low side; low and high end bracket the measured number.
By their numbers in this assay, from the lowest: compounds 3, 1, 2 and 4 (each within the scatter of the next, the first and the last beyond it).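

In this assay, trifluoromethyl in place of hydrogen on the aromatic carbon ortho to a large group gives a 1.7-fold higher number from compound 2 to compound 4 (0.23 log units; within the scatter), and fluoro in place of hydrogen gives a 1.7-fold higher number from compound 1 to compound 4 (0.23 log units; within the scatter). Going by these compounds alone, this position, like the one taken in compound 3, therefore accepts trifluoromethyl without a step beyond the scatter, and the two groups together open no such step from either single-group parent. No measurement at hand accounts for these numbers.

Going by these compounds, whether an amine or a carboxylic acid at this position would leave the scatter stays open.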